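Carbamate ring size and a benzyl swap at the adenosine receptor

The source may hold more compounds than are shown below. What is called first, only, known or untested is meant among the compounds shown, and "the series" means these compounds.

Measured compounds:
compound 1 `O=C(NC1CC1)OC[C@H]1OC(n2cnc3c(NC4CCOC4)ncnc32)[C@H](O)[C@@H]1O` gives 209 nM
compound 2 `O=C(NC1CCC1)OC[C@H]1OC(n2cnc3c(NC4CCOC4)ncnc32)[C@H](O)[C@@H]1O` gives 306 nM
compound 3 `O=C(NC1CCCCC1)OC[C@H]1OC(n2cnc3c(NC4CCOC4)ncnc32)[C@H](O)[C@@H]1O` gives 584 nM

The three measured compounds share one core and differ only in the ring on the amide-type nitrogen of the carbamate. In an assay on DDT1 cells (Cricetulus griseus) for binding affinity to adenosine receptor A1 (Homo sapiens), read by radioligand binding (a lower number here means a stronger inhibitor, a higher number a weaker inhibitor), compound 1 gives 209 nM. Compound 2 carries a cyclobutyl there and in this assay gives 306 nM, and the step of a 1.5-fold higher number from compound 1 to compound 2 (0.17 log units; within the scatter) lies within the scatter. Compound 3 carries a cyclohexyl and in this assay gives 584 nM, the highest of the three numbers; the step of a 2.8-fold higher number from compound 1 to compound 3 (0.45 log units; beyond the scatter) is beyond the scatter, while a 1.9-fold higher number from compound 2 to compound 3 (0.28 log units; within the scatter) is not.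

Compound 4 `O=C(NCc1ccccc1)OC[C@H]1OC(n2cnc3c(NC4CCOC4)ncnc32)[C@H](O)[C@@H]1O` has not been measured. It differs from compound 3 by benzyl in place of cyclohexyl on an amide-type nitrogen. Going by the values given here, no measured step exchanges a saturated ring for an aromatic one, so none bears on it directly; the nearest guide is that enlarging the ring from compound 1 to compound 3 raised the number modestly, and compound 4 again brings a slightly larger group. Compound 4 is therefore expected to sit near compound 3, with the step of a 1.2-fold higher number from compound 3 to compound 4 (0.08 log units; within the scatter) estimated to stay within the scatter. The estimate for compound 4 in this assay is 700 nM, with a range from 250 nM to 2000 nM.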

Compound 4, inhibition constant: 1830 nM
The estimate for compound 4 lay 2.6-fold (0.42 log units) below the measured number, and the stated range covers the measured number.
By their numbers in this assay, from the lowest: compounds 1, 2 and 3 (each within the scatter of the next, the first and the last beyond it); then compound 4.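

In this assay, the benzyl group shows that this position on the amide-type nitrogen is sensitive to more than the size of a saturated ring, with the step of a 3.1-fold higher number from compound 3 to compound 4 (0.50 log units; beyond the scatter) lying beyond the scatter. The gap widens against the smaller rings, with a 6.0-fold higher number from compound 2 to compound 4 (0.78 log units; beyond the scatter) and an 8.8-fold higher number from compound 1 to compound 4 (0.94 log units; beyond the scatter) also printed as beyond the scatter, which makes compound 4 the weakest of the four. Nothing available here gives a reason for this rise.

The compounds shown leave open whether the aromatic ring or the extra carbon between ring and nitrogen accounts for the step, since benzyl differs from cyclohexyl in both. A cyclohexylmethyl or a phenyl on the same nitrogen would separate the two, and a substituted benzyl would show whether the ring tolerates further groups.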